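A few compounds are considered here, and "the series" means these few. Any claim that something is new, unique, unknown or untested is made for them only; others in the source may bear on it.

Among the compounds with values here, compound 2 `CNC(=O)Cn1nc(OC)c2c(NS(=O)(=O)c3cccc(Cl)c3Cl)ncnc21` gives 631 nM in a functional assay on cells for antagonist activity at C-C chemokine receptor type 4 (Homo sapiens), read by GTPgammaS binding (a higher number here means a weaker inhibitor, a lower number a stronger inhibitor), the higher of the two numbers measured so far; compound 1 `COc1nn(C(C)C)c2ncnc(NS(=O)(=O)c3cccc(Cl)c3Cl)c12` gives 251 nM, and the step of a 2.5-fold higher number from compound 1 to compound 2 (0.40 log units; beyond the scatter) was modest. Compound 3 `COCCn1nc(OC)c2c(NS(=O)(=O)c3cccc(Cl)c3Cl)ncnc21` differs from compound 2 by methoxymethyl in place of methylcarbamoyl on a saturated chain carbon bound to an aromatic nitrogen. Within the data shown here, no measured step covers exactly this change; the one step that touches the same chain on the aromatic nitrogen, a 2.5-fold higher number from compound 1 to compound 2 (0.40 log units; beyond the scatter), is the only guide, so a move back toward the number of compound 1 is plausible. For compound 3 a step of a 1.6-fold lower number from compound 2 to compound 3 (0.20 log units; within the scatter) toward a lower number is expected, with an estimate of 400 nM and a range of 150 nM to 1000 nM.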

Compound 3, half-maximal inhibitory concentration: 316 nM
The estimate for compound 3 lay 1.3-fold (0.10 log units) above the measured number; low and high end bracket the measured number.
By their numbers in this assay, from the lowest: compounds 1, 3 and 2 (each within the scatter of the next, the first and the last beyond it).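

In this assay, the step of a 2.0-fold lower number from compound 2 to compound 3 (0.30 log units; within the scatter) and the step of a 1.3-fold higher number from compound 1 to compound 3 (0.10 log units; within the scatter) both stay within the scatter, so 2-methoxyethyl on the aromatic nitrogen cannot be separated from either (methylcarbamoyl)methyl or isopropyl. Replacing methylcarbamoyl with methoxymethyl removes the amide hydrogen without a step beyond the scatter. Nothing available accounts for these steps.

On these data alone, whether an amine, a carboxylic acid or a longer chain at this position would shift the number beyond the scatter remains open.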